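Adding Fluorine to the Phenyl Ring of Compound 1

The source may hold more compounds than are shown below. What is called first, only, known or untested is meant among the compounds shown, and "the series" means these compounds.

Of the compounds shown here, three built on one shared core have been tested in a functional assay on the whole organism (strain Swiss) with Mus musculus as the target, in the maximal electroshock model, with a stated time of 1 h, at a dose of 300 mg/kg by the intraperitoneal route; on this read-out higher numbers stand for a stronger effect at the one dose given and lower numbers for a weaker effect. Compound 1 `CC(C(=O)N1CCN(c2ccccc2)CC1)N1C(=O)CCC1=O` stands highest of the three, giving 50%. Compound 3 `CCC(C(=O)N1CCN(c2ccc(F)cc2)CC1)N1C(=O)CCC1=O` gives 25%, and compound 2 `CCC(C(=O)N1CCN(c2ccc(C(F)(F)F)cc2)CC1)N1C(=O)CCC1=O` gives 0%; both fall beyond the usual scatter below compound 1. For the measured compounds named here, the one step that can be read between two neighbouring structures runs a number 25 percentage points higher from compound 2 to compound 3 (beyond the scatter).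

The new compound, compound 4 `CC(C(=O)N1CCN(c2cccc(F)c2)CC1)N1C(=O)CCC1=O`, differs from compound 1 in a single place: fluoro in place of hydrogen on an aromatic carbon. Going by the values given here, no measured pair shows a fluoro entering in place of hydrogen on this ring, so the step between compound 2 and compound 3 bears only loosely; it compares fluoro with trifluoromethyl, and that pair also carries a longer chain than compound 1 and compound 4. Compound 3 carries a fluoro on its ring and sits below compound 1, yet the two differ in the chain as well, so no single change can be credited for that gap. Without a direct comparison, the expected step from compound 1 to compound 4 is no change at the digits printed from compound 1 to compound 4 (within the scatter), within the scatter. Compound 4 is estimated at 50%, with a range from 25% to 75%.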

Compound 4, a percentage reported as activity, at one dose (the size of the read-out at that dose, not a potency): 75%
Estimate against measurement, compound 4: 25 percentage points below; the range from low to high includes it.
By their numbers in this assay, from the lowest: compound 2; then compound 3; then compound 1; then compound 4.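

In this assay, for the compounds shown here, the one change of a hydrogen to a fluoro on an aromatic carbon, meta to a large group, gives a number 25 percentage points higher from compound 1 to compound 4 (beyond the scatter). Going by these compounds alone, this is the first pair in which fluoro enters in place of hydrogen with the rest of the structure untouched, so the move from phenyl to 3-fluorophenyl can be read on its own, and at this place on the ring it raises the read-out at the one dose given instead of leaving it level. Nothing available here measures a property that could account for the rise.

Still open, on these data alone, is whether the rise belongs to fluoro itself or to this place on the ring: chloro, methoxy or an amine on the same carbon would test the first question, and fluoro on another carbon of the ring would test the second. Also open, as far as these compounds go, is whether the same gain would appear on the longer chain carried by compound 2 and compound 3, and whether it would hold at other doses, since a single-dose percentage is not a potency.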